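Naphthoyl amide in place of cyclohexanecarboxamide on the nitrobenzene core

A few compounds are considered here, and "the series" means these few. Any claim that something is new, unique, unknown or untested is made for them only; others in the source may bear on it.

Working notes on a small set of nitro-substituted anilides and sulfonamides tested in an assay on SK-BR-3 cells for inhibition of Aromatase (Homo sapiens); a higher number here means a weaker inhibitor, a lower number a stronger inhibitor. Compound 1 `Cc1ccc(COc2cc([N+](=O)[O-])ccc2NS(C)(=O)=O)cc1` gives 1750 nM. Compound 2 `CN(c1ccc([N+](=O)[O-])cc1OCc1ccc(-c2ccccc2)cc1)S(C)(=O)=O` gives 650 nM. Compound 3 `O=C(Nc1ccc([N+](=O)[O-])cc1OCc1ccccc1)C1CCCCC1`, the amide of the set, gives only a limit of the assay, > 25000 nM, and no number. Compound 3 thus sits at the limit of > 25000 nM in this assay, at which 1 of the 3 values shown sits; where it stands in relation to compound 1 and compound 2 can only be said to be on the weak side of that limit. Going by the values given here, no single-point step between measured compounds is available in this set, so no measured step size can be quoted.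

Compound 4 `O=C(Nc1ccc([N+](=O)[O-])cc1OCc1ccccc1)c1ccc2ccccc2c1` is the next amide to be measured in this assay. It differs from compound 3 by naphthalen-2-yl in place of cyclohexyl on a carbonyl carbon. The change keeps the amide linkage and the benzyloxy-nitrobenzene core; only the acyl group changes, from a saturated ring to a fused pair of aromatic rings. With compound 3 known only as a limit, the step is expected to be small or none beyond the scatter, towards somewhat lower numbers at best, as an at least 1.2-fold lower number from compound 3 to compound 4 (0.09 log units; that floor lies within the scatter). For compound 4 the expectation in this assay is 20000 nM, with a range from 5000 nM to 80000 nM, and a substantial chance that again only a limit is reported.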

Compound 4, half-maximal inhibitory concentration: > 25000 nM
Compound 4: no number, only a limit; the forecaster's own chance of this, stated with the estimate: 50%; middle value at least 1.2-fold (0.09 log units) from the limit.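

In this assay compound 3 and compound 4 both give only a limit of the assay and no number, so no step can be read for naphthalen-2-yl in place of cyclohexyl: the limit of > 25000 nM in this assay, at which 2 of the 4 values shown sit.

The compounds shown leave open whether any amide on the shared core gives a number in this assay.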